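Ring-nitrogen substituent swap in a thiazole alkyne series

A few compounds are considered here, and "the series" means these few. Any claim that something is new, unique, unknown or untested is made for them only; others in the source may bear on it.

Compound 1, `C(#Cc1nc2c(s1)CN(C1CCCCC1)CC2)c1ccccc1`: in an assay on HEK293 cells for negative allosteric modulation of metabotropic glutamate receptor 5 (Homo sapiens), read by FLIPR, with a stated time of 1 h (a higher number here means a weaker inhibitor, a lower number a stronger inhibitor), a limit, > 10000 nM.
Compound 2, `CC(C)S(=O)(=O)N1CCc2nc(C#Cc3ccccc3)sc2C1`: in this assay 11 nM.

Within the data shown here, compound 2 holds the only numerical value in the set; compound 1 sits at the assay limit, (the limit of > 10000 nM in this assay, at which 1 of the 2 values shown sits). Among the measured compounds shown here, the single measured step, an at least 900-fold lower number from compound 1 to compound 2 (2.95 log units; beyond the scatter), is large and rests on one comparison only.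

Compound 3, `O=C(N1CCCC1)N1CCc2nc(C#Cc3ccccc3)sc2C1`, differs from compound 2 by (pyrrolidin-1-yl)carbonyl in place of isopropylsulfonyl on an amine nitrogen in a ring. For the measured compounds named here, the step from compound 1 to compound 2 is the only one at this place, and it concerns a different exchange, cyclohexyl giving way to isopropylsulfonyl; no measured pair tells how a sulfonyl compares with a carbonyl attached to this ring nitrogen. On that basis the step is expected to be small, in the direction of a higher number, roughly a 2.7-fold higher number from compound 2 to compound 3 (0.44 log units; beyond the scatter).

Compound 3 in this assay is expected to give 30 nM, with a range of 8 nM to 120 nM.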

Compound 3, half-maximal inhibitory concentration: > 10000 nM
Compound 3 was reported as a limit; the forecaster's own chance of this, stated with the estimate: 5%; middle value at least 330-fold (2.52 log units) from the limit.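

At this amine nitrogen in a ring, the result shows that a carbonyl-linked group does not simply stand in for the sulfonyl-linked one: (pyrrolidin-1-yl)carbonyl in place of isopropylsulfonyl gives an at least 900-fold higher number from compound 2 to compound 3 (2.95 log units; beyond the scatter). In this assay compound 3 gives > 10000 nM, which is a limit and not a number. The step between compound 1 and compound 3 cannot be read, and compound 2 remains the only compound in the set with a numerical value: the limit of > 10000 nM in this assay, at which 2 of the 3 values shown sit.

The compounds shown do not tell whether the change in compound 3 follows from the carbonyl link or from the pyrrolidine ring. An isopropylcarbonyl group on this nitrogen would pair directly with compound 2, and a pyrrolidin-1-ylsulfonyl group would pair directly with compound 3, which would separate the two.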